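A few compounds are considered here, and "the series" means these few. Any claim that something is new, unique, unknown or untested is made for them only; others in the source may bear on it.

Of the compounds shown here, three built on a shared core have been tested in a functional assay on MDA-MB-435 cells (Homo sapiens) for cytotoxicity, read by MTT assay, with a stated time of 72 h; a lower number here means a stronger inhibitor, a higher number a weaker inhibitor. Compound 1 `O=C(NCc1ccc(F)cc1)c1nc(NCCO)c2cccnc2c1O` is reported only as a limit, > 20000 nM. Compound 2 `NCCCNc1c(C(=O)NCc2ccc(F)cc2)nc(Br)c2cccnc12` gives a number, 5000 nM, and so does compound 3 `CC(C)(C)OC(=O)N1CCN(c2c(C(=O)NCc3ccc(F)cc3)nc(Br)c3cccnc23)CC1`, at 10000 nM. These two numbers lie within the usual scatter of each other, so compound 2 stands level with compound 3 on this evidence and cannot be ranked against it.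

Compound 4 `N[C@H]1CC[C@H](Nc2c(C(=O)NCc3ccc(F)cc3)nc(Br)c3cccnc23)CC1` has yet to be measured. It carries 4-aminocyclohexyl in place of 3-aminopropyl on a nitrogen on an aromatic ring, the same difference read one bond further out as (3-aminopropyl)amino to (4-aminocyclohexyl)amino: 4-aminocyclohexyl in place of 3-aminopropyl on a nitrogen on an aromatic ring. For the measured compounds named here, no two measured compounds differ in one place only, so the data hold no direct precedent for this exchange. In this assay, no step beyond the scatter is expected and neither direction is favoured, and this expectation rests on compound 2 at 5000 nM. The expected change is small, with the estimated step of a 1.3-fold lower number from compound 2 to compound 4 (0.10 log units; within the scatter). For compound 4 the estimated value is 4000 nM, with an expected range from 1200 nM to 15000 nM.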

Compound 4, half-maximal inhibitory concentration: 6000 nM
Compound 4: middle estimate off by 1.5-fold (0.18 log units), on the low side, and the stated range covers the measured number.
By their numbers in this assay, from the lowest: compounds 2, 4 and 3 (each within the scatter of the next). At a limit, above all of these: compound 1.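

For the compounds shown here, compound 4 gives the first direct reading of a change at this position: in this assay, replacing 3-aminopropyl with 4-aminocyclohexyl on the nitrogen on the aromatic ring gives a 1.2-fold higher number from compound 2 to compound 4 (0.08 log units; within the scatter). The earlier compounds shown here offered no such single-place comparison, whereas this pair shows that a chain with no ring can give way to a six-membered non-aromatic ring of carbon only, with 2 defined stereocentres and more heavy atoms, without a step beyond the scatter, while the count of hydrogen-bond donors and acceptors stays the same. Both compounds give numbers rather than limits, so the step is not cut off by the top of the assay, where the only compound is compound 1, whose value is a limit: the limit of > 20000 nM in this assay, at which 1 of the 4 values shown sits.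

The compounds shown leave open whether the terminal amine matters at this nitrogen, since every group compared here carries one, and a hydroxyl or a carboxylic acid in its place would test that. They also leave open whether a longer chain, or the other stereoisomer of the 4-aminocyclohexyl group, would stay within the scatter of compound 2.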